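A few compounds are considered here, and "the series" means these few. Any claim that something is new, unique, unknown or untested is made for them only; others in the source may bear on it.

Measured compounds:
compound 1 `CC(C)c1c(C(=O)NCC2CCCCC2)nn(-c2ccc(F)cc2)c1OC[C@@H](O)C[C@@H](O)CC(=O)O` 17 nM
compound 2 `CC(C)c1c(C(=O)NCc2cccc(F)c2F)nn(-c2ccc(F)cc2)c1OC[C@@H](O)C[C@@H](O)CC(=O)O` 2 nM
compound 3 `Cc1ccc(CNC(=O)c2nn(-c3ccc(F)cc3)c(OC[C@@H](O)C[C@@H](O)CC(=O)O)c2C(C)C)cc1` 15 nM

In an assay on microsomes from liver for inhibition of 3-hydroxy-3-methylglutaryl-coenzyme A reductase (Rattus norvegicus) (a lower number here means a stronger inhibitor, a higher number a weaker inhibitor), compound 3 gives 15 nM, the second highest of the three numbers. Compound 1 gives 17 nM, and the step of a 1.1-fold lower number from compound 1 to compound 3 (0.05 log units; within the scatter) lies within the scatter. The step of a 7.5-fold higher number from compound 2 to compound 3 (0.88 log units; beyond the scatter) is beyond it, so compound 2 stands apart, with 2 nM.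

Compound 4 `CC(C)c1c(C(=O)N2CCC[C@H](c3ccccc3)C2)nn(-c2ccc(F)cc2)c1OC[C@@H](O)C[C@@H](O)CC(=O)O` is not yet measured. It differs from compound 3 by 3-phenylpiperidin-1-yl in place of (4-methylbenzyl)amino on a carbonyl carbon. All three measured steps change only the group on the saturated chain carbon bound to the amide-type nitrogen; the largest among them, an 8.5-fold lower number from compound 1 to compound 2 (0.93 log units; beyond the scatter), and a 7.5-fold higher number from compound 2 to compound 3 (0.88 log units; beyond the scatter) are modest, while a 1.1-fold lower number from compound 1 to compound 3 (0.05 log units; within the scatter) is within the scatter. For the measured compounds named here, none of them replaces the (4-methylbenzyl)amino group itself, so no measured step bears directly on this change. The step of a 2.7-fold higher number from compound 3 to compound 4 (0.43 log units; beyond the scatter) is therefore estimated cautiously, with a wide range. For compound 4 the expected value in this assay is 40 nM, between 8 nM and 200 nM.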

Compound 4, half-maximal inhibitory concentration: 4.8 nM
Compound 4: middle estimate off by 8.3-fold (0.92 log units), on the high side; the measured number lies below the stated range.
By their numbers in this assay, from the lowest: compound 2; then compound 4; then compounds 3 and 1 (each within the scatter of the next).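

In this assay, the carbonyl carbon accepts a cyclic 3-phenylpiperidin-1-yl group, which has a defined stereocentre and no hydrogen-bond donor, in place of the open amino groups, and the number still falls for two of the three comparisons (a 3.1-fold lower number from compound 3 to compound 4 (0.49 log units; beyond the scatter); a 3.5-fold lower number from compound 1 to compound 4 (0.55 log units; beyond the scatter)). The (2,3-difluorobenzyl)amino group goes against this, as the number rises on replacing it (a 2.4-fold higher number from compound 2 to compound 4 (0.38 log units; beyond the scatter)), so the outcome depends on which group leaves. No measurement here gives a reason for these steps.

The compounds shown leave open whether the lower numbers follow from the piperidine ring or from the loss of the amide hydrogen, which a methyl(4-methylbenzyl)amino group on the same carbonyl carbon would separate. They also leave open how the opposite enantiomer of the 3-phenylpiperidin-1-yl group would compare.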